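Swapping the benzyl ether aryl group in a thiourea series

The source may report more compounds than this note shows. Statements on the series, on what has been measured and on what is new or still open speak of the compounds shown alone.

Compound 1 `Cc1ccc(NC(=S)NC(=O)c2ccc(OCc3ccccc3F)cc2)cc1-c1nc2ccccc2[nH]1`: 2420 nM
Compound 2 `Cc1ccc(COc2ccc(C(=O)NC(=S)Nc3ccc(C)c(-c4nc5ccccc5[nH]4)c3)cc2)cc1`: 11300 nM

Both were measured in a functional assay on MNK45 cells (Homo sapiens) for inhibition, read by MTT assay, with a stated time of 48 h; on this read-out lower numbers stand for stronger inhibition and higher numbers for weaker inhibition. Compound 2 gives the highest of the two numbers; the nearest is compound 1, a step recorded as a 4.7-fold higher number from compound 1 to compound 2 (0.67 log units; beyond the scatter). Compound 3 `Cc1ccc(NC(=S)NC(=O)c2ccc(OCc3ccc(Cl)c(Cl)c3)cc2)cc1-c1nc2ccccc2[nH]1` differs from compound 2 by 3,4-dichlorophenyl in place of 4-methylphenyl on a saturated chain carbon bound to an oxygen on an aromatic ring. For the measured compounds named here, only that one step bears on this change, and it shows that swapping the aryl group here moves the number modestly. A modest lower number is therefore expected, though it may stay within the scatter; the expected step is a 2.3-fold lower number from compound 2 to compound 3 (0.35 log units; beyond the scatter). Compound 3 is estimated at 5000 nM, with a range from 1500 nM to 17000 nM.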

Compound 3, half-maximal inhibitory concentration: 8410 nM
The estimate for compound 3 lay 1.7-fold (0.23 log units) below the measured number, and the stated range covers the measured number.
By their numbers in this assay, from the lowest: compound 1; then compounds 3 and 2 (each within the scatter of the next).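

The step from 4-methylphenyl to 3,4-dichlorophenyl reads a 1.3-fold lower number from compound 2 to compound 3 (0.13 log units; within the scatter) and so does not separate these two aryl groups. Against 2-fluorophenyl, the new group shows a 3.5-fold higher number from compound 1 to compound 3 (0.54 log units; beyond the scatter) and this, with the earlier step, leaves compound 1 apart from both other compounds on steps beyond the scatter. Nothing available explains why this difference arises.

Still open, from the compounds shown here alone, is whether a plain phenyl, or a phenyl carrying a carboxylic acid, at this place would match compound 1 or fall with compound 2 and compound 3.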